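This account rests on a few compounds, and the source may have more. Where it says the series, first, only, none or still open, it means among the compounds named here.

Compound 1 `CN(C)C(=O)c1cccnc1NCCCN1CCN(c2ccccc2)CC1` gives 15.9 nM in a functional assay on aorta for antagonist activity at Alpha-1D adrenergic receptor (Rattus norvegicus); on this read-out lower numbers stand for tighter binding and higher numbers for weaker binding. Compound 2 `CCOc1ccccc1N1CCN(CCCNc2ncccc2C(=O)N(C)C)CC1` gives 7.94 nM in this assay, and compound 3 `CC(C)c1ccccc1N1CCN(CCCNc2ncccc2C(=O)N(C)C)CC1` gives 63.1 nM in this assay, the highest of the three numbers. The step of a 2.0-fold lower number from compound 1 to compound 2 (0.30 log units; within the scatter) stays small, whereas a 4.0-fold higher number from compound 1 to compound 3 (0.60 log units; beyond the scatter) and a 7.9-fold higher number from compound 2 to compound 3 (0.90 log units; beyond the scatter) both lie beyond the scatter. Compound 4 `COc1ccc(N2CCN(CCCNc3ncccc3C(=O)N(C)C)CC2)c(OC)c1` carries 2,4-dimethoxyphenyl in place of 2-isopropylphenyl on an amine nitrogen in a ring. Among the compounds with values here, the two steps ending at compound 3 bear on this change, since the isopropyl group that leaves was the one that raised the numbers, while the methoxy groups that enter resemble the ethoxy of compound 2. Compound 4 is therefore expected to give about 10 nM in this assay, between 4 nM and 30 nM, because a 7.9-fold higher number from compound 2 to compound 3 (0.90 log units; beyond the scatter) ran the opposite way. For compound 4 this estimate means a 6.3-fold lower number from compound 3 to compound 4 (0.80 log units; beyond the scatter).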

Compound 4, dissociation constant: 1000 nM
Estimate against measurement, compound 4: 100-fold (2.00 log units) below, and the stated range ends below it.
By their numbers in this assay, from the lowest: compounds 2 and 1 (each within the scatter of the next); then compound 3; then compound 4.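

In this assay the change to 2,4-dimethoxyphenyl gives a 16-fold higher number from compound 3 to compound 4 (1.20 log units; beyond the scatter) and also a 130-fold higher number from compound 2 to compound 4 (2.10 log units; beyond the scatter) and a 63-fold higher number from compound 1 to compound 4 (1.80 log units; beyond the scatter) on the same ring nitrogen, which puts this group above every other aryl group shown. Oxygen on the phenyl ring therefore does not by itself keep the number low at this position, as compound 2 alone might have suggested. Nothing available here explains this rise. The compounds shown leave open whether a phenyl ring carrying a single methoxy group would sit with compound 2 or with compound 4.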